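A Sec-Butyl Ester Added to Compound 2

The source may hold more compounds than are shown below. What is called first, only, known or untested is meant among the compounds shown, and "the series" means these compounds.

Compound 2 `C=C1C(=O)O[C@@H]2CC(C)=C([C@@H](C)CCCO)[C@H](O)[C@H]12` was tested in a functional assay on HL-60 cells (Homo sapiens) for activation, read by flow cytometry, with a stated time of 24 h, tested at 100 uM (a higher number here means a stronger effect of the compound at the concentration tested, a lower number a weaker effect), where compound 2 gives 12.8%. Compound 1 `C=C1C(=O)O[C@@H]2CC(C)=C([C@@H](C)CCCOC(C)=O)[C@H](OC(C)=O)[C@H]12` gives 22.2%, a number that sits within the usual scatter of the result for compound 2, so the two cannot be told apart. Compound 3 `C=C1C(=O)O[C@@H]2CC(C)=C([C@@H](C)CCCO)[C@H](OC(=O)C(C)CC)[C@H]12` has not yet been measured. It differs from compound 2 in one place: (sec-butyl)carbonyl in place of hydrogen on an oxygen on a saturated carbon, so hydroxy becomes ((sec-butyl)carbonyl)oxy. Going by the values given here, no measured step of this kind exists here, and the expected step is a number 7.2 percentage points higher from compound 2 to compound 3 (within the scatter), a modest rise that need not clear the scatter. Compound 3 is estimated at 20%, somewhere between 8% and 35%.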

Compound 3, a percentage reported as activity, at one concentration (the size of the read-out at that concentration, not a potency): 27.1%
For compound 3 the middle estimate is 7.1 percentage points below the measured one, and the stated range covers the measured number.
By their numbers in this assay, from the lowest: compounds 2, 1 and 3 (each within the scatter of the next, the first and the last beyond it).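

In this assay, going by these compounds alone, putting (sec-butyl)carbonyl on this oxygen gives a number 14.3 percentage points higher from compound 2 to compound 3 (beyond the scatter), the first step here that is larger than the scatter. So turning this hydroxy into an ester can raise the read-out at the concentration tested, and the free hydrogen on this oxygen is not needed for the effect. No available data explain the rise. On these data alone, whether it depends on the sec-butyl group or would come with any ester here stays open. An acetyl or benzoyl group alone at this oxygen would test that.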